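A few compounds are considered here, and "the series" means these few. Any claim that something is new, unique, unknown or untested is made for them only; others in the source may bear on it.

Within the data shown here, in a functional assay on CCRF-CEM cells (Homo sapiens) for inhibition (on this read-out higher numbers stand for weaker inhibition and lower numbers for stronger inhibition), compound 2 `O=C1O/C(=C\Cn2ccc(=O)[nH]c2=O)C(OCc2ccccc2)=C1OCc1ccccc1` gives 13000 nM, the higher of the two numbers so far, which makes it the weaker inhibitor of the pair. Its iodo relative, compound 1 `O=C1O/C(=C\Cn2cc(I)c(=O)[nH]c2=O)C(OCc2ccccc2)=C1OCc1ccccc1`, gives 3300 nM. Compound 3 `O=C1O/C(=C\Cn2cc(Cl)c(=O)[nH]c2=O)C(OCc2ccccc2)=C1OCc1ccccc1` has not yet been measured. It differs from compound 2 by a single swap, chloro in place of hydrogen on an aromatic carbon. Among the measured compounds shown here, one measured step bears on this swap, because hydrogen replaced iodo on that same carbon in a 3.9-fold higher number from compound 1 to compound 2 (0.60 log units; beyond the scatter). Read in reverse, this step suggests that putting chloro on that carbon should lower the number, though a single pair is thin evidence and chloro is not iodo. The expected change is of similar or somewhat smaller size, a 2.4-fold lower number from compound 2 to compound 3 (0.37 log units; beyond the scatter). For compound 3 the estimated value is 5500 nM, with an expected range from 2500 nM to 12000 nM.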

Compound 3, half-maximal inhibitory concentration: 6000 nM
Compound 3: the middle estimate sits 1.1-fold (0.04 log units) below what was measured; low and high end bracket the measured number.
By their numbers in this assay, from the lowest: compounds 1 and 3 (each within the scatter of the next); then compound 2.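

The step of a 2.2-fold lower number from compound 2 to compound 3 (0.34 log units; beyond the scatter) in this assay shows that the earlier iodo result does not stand alone: a second halogen on this aromatic carbon also goes with a lower number than the hydrogen of compound 2. The size of the halogen atom's effect cannot be ranked from these compounds, and chloro and iodo cannot be told apart on this read-out, as the change is a 1.8-fold higher number from compound 1 to compound 3 (0.26 log units; within the scatter). No measurement at hand gives a reason for this effect of the two halogens.

On these data alone, whether the lower number needs a halogen at all stays open, and a methyl group, an amine or a trifluoromethyl group on the same carbon would help to settle that. As far as these compounds go, how fluoro or bromo would compare with chloro and iodo on this carbon also remains unknown.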